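Swapping the aryl cap: from trifluoromethylphenyl to fluorophenyl

The source may hold more compounds than are shown below. What is called first, only, known or untested is meant among the compounds shown, and "the series" means these compounds.

Compound 1 `COc1cc2c(Oc3ccc(NC(=O)c4nn(-c5ccccc5)c(=O)cc4C)cc3F)ccnc2cc1OCCCN1CCCC1` gives 1100 nM in a functional assay on U-87MG ATCC cells (Homo sapiens) for inhibition, read by MTT assay, with a stated time of 72 h; a higher number here means a weaker inhibitor, a lower number a stronger inhibitor. Compound 2 `COc1cc2c(Oc3ccc(NC(=O)c4nn(-c5ccccc5C(F)(F)F)c(=O)cc4C)cc3F)ccnc2cc1OCCCN1CCCC1` gives 1010 nM, and compound 3 `COc1cc2c(Oc3ccc(NC(=O)c4nn(-c5ccccc5C(F)(F)F)c(=O)cc4C)cc3F)ccnc2cc1OCCCN1CCN(C)CC1` gives 1170 nM. The step of a 1.1-fold lower number from compound 1 to compound 2 (0.04 log units; within the scatter) and the step of a 1.2-fold higher number from compound 2 to compound 3 (0.06 log units; within the scatter) both stay within the scatter, so compound 2 sits within the usual spread of both compound 1 and compound 3. Compound 4 `COc1cc2c(Oc3ccc(NC(=O)c4nn(-c5cccc(F)c5)c(=O)cc4C)cc3F)ccnc2cc1OCCCN1CCCC1` differs from compound 2 by one change: 3-fluorophenyl in place of 2-(trifluoromethyl)phenyl on an aromatic nitrogen. Within the data shown here, the only measured step touching that same phenyl ring, a 1.1-fold lower number from compound 1 to compound 2 (0.04 log units; within the scatter), was within the scatter, so the expected step of a 1.1-fold higher number from compound 2 to compound 4 (0.04 log units; within the scatter) is none beyond the scatter. Compound 4 is therefore estimated at 1100 nM, with a range from 550 nM to 2200 nM.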

Compound 4, half-maximal inhibitory concentration: 1700 nM
For compound 4 the middle estimate is 1.5-fold (0.19 log units) below the measured one; the measured number falls inside the stated range.
By their numbers in this assay, from the lowest: compounds 2, 1, 3 and 4 (each within the scatter of the next).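

In this assay the step of a 1.7-fold higher number from compound 2 to compound 4 (0.23 log units; within the scatter) exchanges one substituted phenyl ring for another on the aromatic nitrogen, and the step of a 1.5-fold higher number from compound 1 to compound 4 (0.19 log units; within the scatter) puts a fluoro on the plain phenyl ring. This position has now carried three different aryl caps, and the numbers do not separate them, even with a fluoro in place of a trifluoromethyl on a different ring carbon. No evidence is available to explain these small steps.

Still open, from the compounds shown here alone, is whether an amine or a carboxylic acid on this phenyl ring would move the number beyond the scatter. The same question stands for a saturated cyclohexyl ring in place of the phenyl.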